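The source may report more compounds than this note shows. Statements on the series, on what has been measured and on what is new or still open speak of the compounds shown alone.

Compound 1 `Oc1ccc(-c2cc(-c3cccc(O)c3)cc(-c3cccc(O)c3)n2)cc1` and compound 3 `Oc1ccc(-c2cc(-c3cccc(O)c3)nc(-c3ccccc3O)c2)cc1` are built from the same atoms joined differently; the difference between their two cores is not broken down here. In an ADME assay on HEK293 cells (Homo sapiens) for cytotoxicity, read by CCK-8 assay, with a stated time of 4 days (on this read-out lower numbers stand for stronger inhibition and higher numbers for weaker inhibition), compound 1 gives 1560 nM. In this assay compound 3 gives 7420 nM, the higher of the two numbers read. Compound 2 `Oc1ccc(-c2cc(-c3cccc(O)c3)cc(-c3ccc(O)cc3)n2)cc1` arises from compound 1 by 4-hydroxyphenyl in place of 3-hydroxyphenyl on an aromatic carbon. In this assay compound 2 reaches only a limit of the assay, > 50000 nM; this is the limit of > 50000 nM in this assay, at which 1 of the 3 values shown sits. The change thus produced an at least 32-fold higher number from compound 1 to compound 2 (1.50 log units; beyond the scatter). Compound 4 `Oc1ccc(-c2cc(-c3ccc(O)cc3)nc(-c3ccccc3O)c2)cc1` arises from compound 3 by the same kind of change, (4-hydroxyphenyl in place of 3-hydroxyphenyl on an aromatic carbon); here the place is meta to a 2-hydroxyphenyl group where in compound 1 it was meta to a 3-hydroxyphenyl group, so the change is of the same kind, not the same. Starting from the higher number of compound 3, a step of the size seen from compound 1 to compound 2 would carry compound 4 to a very high number. Compound 4 is therefore expected to give 120000 nM in this assay, with a range from 30000 nM to 500000 nM. The expected step is a 16-fold higher number from compound 3 to compound 4 (1.21 log units; beyond the scatter). This rests on compound 3 with 7420 nM and on an at least 32-fold higher number from compound 1 to compound 2 (1.50 log units; beyond the scatter).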

Compound 4, half-maximal inhibitory concentration: 26300 nM
For compound 4 the middle estimate is 4.6-fold (0.66 log units) above the measured one; the measured number lies below the stated range.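

In this assay the change from 3-hydroxyphenyl to 4-hydroxyphenyl again gives a higher number, with a 3.5-fold higher number from compound 3 to compound 4 (0.55 log units; beyond the scatter), so its direction carries over to the second core while its size does not: the same change on two cores in this assay, an at least 32-fold higher number (1.50 log units; beyond the scatter) from compound 1 to compound 2 and a 3.5-fold higher number (0.55 log units; beyond the scatter) from compound 3 to compound 4, at least 9.0-fold (0.95 log units) apart, beyond the scatter of two such steps. The earlier step has no upper end, since the value of compound 2 is a limit of the assay, and so only the smallest possible gap between the two steps is known: the limit of > 50000 nM in this assay, at which 1 of the 4 values shown sits. With one pair on each core, the series shows that the size of this change cannot simply be carried from one core to another, but it does not show what in the cores sets that size.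

As far as these compounds go, it remains open whether the size of the step depends on the 2-hydroxyphenyl group of compound 3 and compound 4 or on some other feature of the core. Also open, from the compounds shown here alone, is how the number would move if a methoxy group or an amine stood in place of the hydroxyl on the moved ring.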